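The compounds below may be only part of what the source reports. "The series", "measured", "known", "first", "only" and "open" are said of these compounds alone.

Among the compounds with values here, the two compounds measured so far share one core, and neither has given a number. Compound 1 `Cc1nc(N)c2c(-c3ccco3)cn([C@@H]3O[C@H](CO)[C@@H](O)[C@H]3O)c2n1` carries a furan-2-yl group on that core. In a functional assay on A549 cells (Homo sapiens), read by MTT assay, with a stated time of 72 h (a higher number here means a weaker inhibitor, a lower number a stronger inhibitor), compound 1 gives > 20000 nM, which is a limit of the assay rather than a measured number. Compound 2 `Nc1nc(N)c2c(-c3ccccc3)cn([C@@H]3O[C@H](CO)[C@@H](O)[C@H]3O)c2n1` differs from compound 1 at two places. In this assay compound 2 gives > 20000 nM, again a limit and not a number. The whole record therefore stands at one boundary: the limit of > 20000 nM in this assay, at which 2 of the 2 values shown sit, and compound 1 sits there together with compound 2, so no order between them can be stated.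

Compound 3 `Cc1nc(N)c2c(-c3cc4ccccc4o3)cn([C@@H]3O[C@H](CO)[C@@H](O)[C@H]3O)c2n1` differs from compound 1 by 1-benzofuran-2-yl in place of furan-2-yl on an aromatic carbon. Within the data shown here, no step between two measured compounds is available, so the size of such a change cannot be read from what has been measured. The step from compound 1 to compound 3 is expected to be an at least 1.6-fold lower number from compound 1 to compound 3 (0.22 log units; that floor lies within the scatter), a modest gain that may not exceed the scatter. Compound 3 is expected to give 12000 nM, in a range from 2500 nM to 20000 nM, and it may again be reported only as a limit.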

Compound 3, half-maximal inhibitory concentration: > 20000 nM
Compound 3: only a limit was reported; the forecaster's own chance of this, stated with the estimate: 55%; middle value at least 1.6-fold (0.22 log units) from the limit.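

In this assay compound 3 gives > 20000 nM and this is a limit of the assay, not a number. No step can be read from compound 1 to compound 3, since both sit at the same boundary: the limit of > 20000 nM in this assay, at which 3 of the 3 values shown sit. The compounds shown leave open whether any change on the shared core would give a measured number in this assay at all.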